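This account rests on a few compounds, and the source may have more. Where it says the series, first, only, none or still open, it means among the compounds named here.

Working notes on the series. Compound 1 `CC(=O)OC[C@H]1O[C@H](OC[C@@H](Cn2cc(CN(c3nc(-c4ccc([N+](=O)[O-])cc4)no3)C3CCCCC3)nn2)OC(C)=O)C=C[C@@H]1OC(C)=O` and compound 2 `CC(=O)OC[C@H]1O[C@H](OC[C@@H](Cn2cc(CN(c3nc(-c4ccc(Cl)cc4)no3)C3CCCCC3)nn2)OC(C)=O)C=C[C@@H]1OC(C)=O` share one core and differ only in the substituent on the phenyl ring. In an ADME assay on HepG2 cells (Homo sapiens) for cytotoxicity, read by MTT assay, with a stated time of 48 h (a higher number here means that more compound is tolerated, a lower number that less compound is tolerated), compound 1 gives only a limit, > 200 ug/mL, and no number. In this assay compound 2 gives 46.9 ug/mL, which is the only number shown in the set. The other value, that of compound 1, is a limit of this assay (the limit of > 200 ug/mL in this assay, at which 1 of the 2 values shown sits). For the measured compounds named here, the one measured step, an at least 4.2-fold lower number from compound 1 to compound 2 (0.62 log units; beyond the scatter), is therefore itself only a bound on how far the nitro-to-chloro exchange moves the read-out.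

Compound 3 `CC(=O)OC[C@H]1O[C@H](OC[C@@H](Cn2cc(CN(c3nc(-c4ccc(F)cc4)no3)C3CCCCC3)nn2)OC(C)=O)C=C[C@@H]1OC(C)=O` is not yet measured. It differs from compound 2 by fluoro in place of chloro on an aromatic carbon. Going by the values given here, no measured step involves a fluoro group, and the step from compound 1 to compound 2 concerns a different exchange, so it sets only the scale on which substituent changes at this position have shifted this assay, not the direction for a chloro-to-fluoro swap. With nothing in the data pointing either way, the expectation is a step of a 1.2-fold higher number from compound 2 to compound 3 (0.07 log units; within the scatter) that stays within the scatter. Compound 3 is estimated at 55 ug/mL in this assay, expected to fall between 22 ug/mL and 140 ug/mL.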

Compound 3, half-maximal cytotoxic concentration: 28.8 ug/mL
Estimate against measurement, compound 3: 1.9-fold (0.28 log units) above; measured number inside the range.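

In this assay, for the compounds shown here, a 1.6-fold lower number from compound 2 to compound 3 (0.21 log units; within the scatter) is the only step that joins two actual numbers, and it shows that the exchange between the two halogens at this place, para to a large group, leaves compound 2 and compound 3 not distinguishable. The other new step, an at least 6.9-fold lower number from compound 1 to compound 3 (0.84 log units; beyond the scatter), shows that the nitro group of compound 1 separates from fluoro as well as from chloro, so compound 1 stands apart from both halogen compounds, while neither halogen stands apart from the other. Compound 1 gives only a limit, so both of its steps remain bounds, and their full size cannot be read: the limit of > 200 ug/mL in this assay, at which 1 of the 3 values shown sits.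

The compounds shown carry only nitro, chloro and fluoro on this phenyl ring, so the read-out in this assay with an amine, a carboxylic acid or a methoxy group at the same place remains open. From the compounds shown here alone, all three compounds also share the rest of the core unchanged, so whether the small step between the halogens would hold on a different core also remains open.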